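Replacing the carboxy group of a fatty-acid amide hydrolase inhibitor

The source may hold more compounds than are shown below. What is called first, only, known or untested is meant among the compounds shown, and "the series" means these compounds.

Measured compounds:
- compound 1, `O=C(COc1ccc(Oc2ccccc2)cc1)Cn1ncc2cc(C(=O)O)ccc21`: 55 nM
- compound 2, `O=C(COc1ccc(Oc2ccccc2)cc1)Cn1ncc2cc(NC(=O)CO)ccc21`: 5400 nM
- compound 3, `O=C(COc1ccc(Oc2ccccc2)cc1)Cn1ncc2cc([N+](=O)[O-])ccc21`: 550 nM

In an assay on microsomes from brain for inhibition of Fatty-acid amide hydrolase 1 (Rattus norvegicus), read by fluorescence and HPLC, with a stated time of 45 min (on this read-out higher numbers stand for weaker inhibition and lower numbers for stronger inhibition), compound 1 gives the lowest number of the three, with compound 3 nearest and compound 2 furthest from it. Compound 4, `O=C(COc1ccc(Oc2ccccc2)cc1)Cn1ncc2cc(NC(=O)NC3CCCCC3)ccc21`, differs from compound 1 only at the substituent on the fused benzene-type ring: (cyclohexylcarbamoyl)amino in place of carboxy on an aromatic carbon.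

Among the compounds with values here, two measured steps bear on this change, as both swap the same carboxy group for an uncharged substituent. The step of a 98-fold higher number from compound 1 to compound 2 (1.99 log units; beyond the scatter) is large, and the step of a 10-fold higher number from compound 1 to compound 3 (1.00 log units; beyond the scatter) is modest. Neither group is a (cyclohexylcarbamoyl)amino group, but both replacements weakened inhibition, the amide-bearing one most. A weakening beyond the scatter is therefore expected for compound 4, probably between the sizes of those two steps, so that the expected step is a 27-fold higher number from compound 1 to compound 4 (1.44 log units; beyond the scatter).

Compound 4 is thus estimated at 1500 nM in this assay, within a range of 300 nM to 8000 nM.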

Compound 4, half-maximal inhibitory concentration: 840 nM
Compound 4: middle estimate off by 1.8-fold (0.25 log units), on the high side; low and high end bracket the measured number.
By their numbers in this assay, from the lowest: compound 1; then compounds 3 and 4 (each within the scatter of the next); then compound 2.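

In this assay a substituent carrying a six-membered carbon ring can sit on this aromatic carbon and still give a 15-fold higher number from compound 1 to compound 4 (1.18 log units; beyond the scatter) as the price of losing the carboxy group. The added ring brings no clear difference from the much smaller nitro group, as a 1.5-fold higher number from compound 3 to compound 4 (0.18 log units; within the scatter) is the step between them. Within the data shown here, changing only the end of the substituent, cyclohexylamino in place of hydroxymethyl on a carbonyl carbon, gives a 6.4-fold lower number from compound 2 to compound 4 (0.81 log units; beyond the scatter) and so shows for the first time that the far end of this group affects the number.

Open, going by these compounds, is whether a simple amine here, or a (cyclohexylcarbamoyl)amino group with a carboxylic acid on its ring, would return toward the number of compound 1. No measurement shown accounts for any of these differences.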